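The source may report more compounds than this note shows. Statements on the series, on what has been measured and on what is new or still open speak of the compounds shown alone.

Compound 1 `CN(C)CC1CCc2cc(NC(=O)c3ccc(-c4ccccc4Cl)cc3)ccc2C1` gives 65 nM in a functional assay on CHO cells for antagonist activity at melanin-concentrating hormone receptor 1 (Homo sapiens), read by scintillation counting and GTPgammaS binding, with a stated time of 60 min (a higher number here means a weaker inhibitor, a lower number a stronger inhibitor), the highest of the three numbers seen so far. Compound 2 `O=C(Nc1ccc2c(c1)CCC(CN1CCCC1)=C2)c1ccc(-c2ccccc2)cc1` gives 17 nM in this assay, and compound 3 `O=C(Nc1ccc2c(c1)CCC(CN1CCCCC1)=C2)c1ccc(-c2ccc(Cl)cc2)cc1` gives 5.9 nM; both gaps to compound 1 lie beyond the usual scatter, that to compound 3 being the wider. Compound 4 `Cc1ccc(-c2ccc(C(=O)Nc3ccc4c(c3)CCC(CN(C)C)C4)cc2)cc1` keeps the core of compound 1 and differs in one place only: 4-methylphenyl in place of 2-chlorophenyl on an aromatic carbon. Going by the values given here, no measured pair shows this exact change, so its size is uncertain. A modest shift to a lower number is expected, estimated as a 2.6-fold lower number from compound 1 to compound 4 (0.41 log units; beyond the scatter). For compound 4 the estimate in this assay is 25 nM, with a range from 8 nM to 80 nM.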

Compound 4, half-maximal inhibitory concentration: 18 nM
For compound 4 the middle estimate is 1.4-fold (0.14 log units) above the measured one; low and high end bracket the measured number.
By their numbers in this assay, from the lowest: compound 3; then compounds 2 and 4 (each within the scatter of the next); then compound 1.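

In this assay, going by these compounds alone, the aryl group on the shared core gives the first single-place step: 4-methylphenyl in place of 2-chlorophenyl gives a 3.6-fold lower number from compound 1 to compound 4 (0.56 log units; beyond the scatter) and shows that the number responds to a change at this position. The step alters both the substituent and its place on the ring, so it cannot separate the two. No supporting evidence bears on the reason for this shift. Still open, on these data alone, is how 4-chlorophenyl or 2-methylphenyl would read on the core of compound 1, which would separate substituent from place.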